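Methoxy for Methyl Repeated on a Second Naphthalene Core

This account rests on a few compounds, and the source may have more. Where it says the series, first, only, none or still open, it means among the compounds named here.

Compound 1 `C=C(c1cccc2ccccc12)C1CCC2(CC1)COC(Nc1ccc(C)cc1)OO2`: 6.08
Compound 2 `C=C(c1cccc2ccccc12)C1CCC2(CC1)COC(Nc1ccc(OC)cc1)OO2`: 5.46
Compound 3 `C=C(c1ccc2ccccc2c1)C1CCC2(CC1)COC(Nc1ccc(C)cc1)OO2`: 6.08

Of the compounds shown here, three have been measured in a physicochemical assay for lipophilicity; a lower number here means a more polar compound, a higher number a more lipophilic compound. Compound 2 differs from compound 1 by methoxy in place of methyl on an aromatic carbon, and this change gave a number 0.62 log units lower from compound 1 to compound 2 (beyond the scatter). Compound 3 differs from compound 1 in its core, the two having the same atoms joined differently: naphthalen-2-yl in place of naphthalen-1-yl on a double-bonded chain carbon bound to a saturated ring carbon. That change gave no change at the digits printed from compound 1 to compound 3 (within the scatter), so compound 1 and compound 3 stand level, together the highest of the three numbers, with compound 2 furthest from compound 3.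

Compound 4 `C=C(c1ccc2ccccc2c1)C1CCC2(CC1)COC(Nc1ccc(OC)cc1)OO2` has not yet been measured in this assay. It differs from compound 3 by methoxy in place of methyl on an aromatic carbon. This is the same change as the one from compound 1 to compound 2, and among the compounds shown it occurs twice; the place of the change is described in the same words in both cases, so it is the same change made on the core of compound 3 rather than on the core of compound 1.

Compound 4 is expected to sit below compound 3 by a number 0.62 log units lower from compound 3 to compound 4 (beyond the scatter), because the same change showed a number 0.62 log units lower from compound 1 to compound 2 (beyond the scatter) on the core of compound 1, and because compound 3 showed no change at the digits printed from compound 1 to compound 3 (within the scatter), which gives no sign that the core of compound 3 behaves differently. Compound 4 is therefore estimated at 5.46, with the range from 5.15 to 5.75.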

Compound 4, partition coefficient: 5.46
For compound 4 middle estimate and measured number coincide at the digits printed; the measured number falls inside the stated range.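

In this assay, methoxy in place of methyl on the core of compound 3 gave a number 0.62 log units lower from compound 3 to compound 4 (beyond the scatter) and so repeated, at the digits printed, the step on the core of compound 1, which was a number 0.62 log units lower from compound 1 to compound 2 (beyond the scatter). Read the other way, naphthalen-2-yl in place of naphthalen-1-yl gave no change at the digits printed from compound 2 to compound 4 (within the scatter) in the methoxy pair, just as it gave no change at the digits printed from compound 1 to compound 3 (within the scatter) in the methyl pair, so across these four compounds the two changes add up without any visible interaction. This shows that the step carried over between two cores that differ only in how the naphthalene is attached, but it does not show that the step would hold on a core of another kind, and nothing at hand explains the agreement.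

The compounds shown leave open whether a group other than methoxy, such as an amine or a carboxylic acid, would also give the same step on both cores when it stands in place of methyl on the aromatic carbon. They also leave open whether the step would survive if a longer chain took the place of the naphthalene group on the double-bonded chain carbon.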